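From 3,5-dimethoxybenzyl to allyl: a step from a limit

This account rests on a few compounds, and the source may have more. Where it says the series, first, only, none or still open, it means among the compounds named here.

In a functional assay on HCT-116 cells (Homo sapiens) for inhibition, read by sulforhodamine B assay, with a stated time of 48 h (on this read-out lower numbers stand for stronger inhibition and higher numbers for weaker inhibition), compound 3 (`COc1cc(COC(c2ccc(OC)c(OC)c2OC)c2cccc3ccccc23)cc(OC)c1`) gives > 20000 nM, which is a limit of the assay and not a number. Compound 1 (`COc1ccc(C(OCc2ccccc2)c2cccc3ccccc23)c(OC)c1OC`) gives > 20000 nM, again a limit. Within the data shown here, compound 2 (`COc1ccc(C(c2ccc(O)cc2)c2cccc3ccccc23)c(OC)c1OC`) gives 16000 nM, the only actual number so far. Together, these results show (the limit of > 20000 nM in this assay, at which 2 of the 3 values shown sit).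

Compound 4 (`C=CCOC(c1ccc(OC)c(OC)c1OC)c1cccc2ccccc12`) has not yet been measured. It carries vinyl in place of 3,5-dimethoxyphenyl on a saturated chain carbon bound to an oxygen on a saturated carbon, so the 3,5-dimethoxybenzyl group gives way to allyl: vinyl in place of 3,5-dimethoxyphenyl on a saturated chain carbon bound to an oxygen on a saturated carbon.

Among the measured compounds shown here, two measured steps bear on this change. The closer one alters the same place, yet it is a step that the two limits leave unreadable from compound 1 to compound 3. The other, which replaces benzyloxy with 4-hydroxyphenyl, is an at least 1.2-fold lower number from compound 1 to compound 2 (0.09 log units; that floor lies within the scatter). Neither shows a change at that place that clearly moves the read-out, so no shift beyond the scatter is expected in this assay. The estimated step is an at least 1.2-fold lower number from compound 3 to compound 4 (0.09 log units; that floor lies within the scatter), and no firm direction is expected. Compound 4 is estimated at 16000 nM, with an expected range from 7000 nM to 30000 nM.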

Compound 4, half-maximal inhibitory concentration: > 20000 nM
Compound 4: only a limit was reported; the forecaster's own chance of this, stated with the estimate: 55%; middle value at least 1.2-fold (0.09 log units) away from the limit.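

Replacing the 3,5-dimethoxybenzyl group with allyl takes away one six-membered aromatic ring at this place, and in this assay compound 4 gives > 20000 nM, which is a limit of the assay and not a number. Compound 1, compound 3 and compound 4 carry benzyl, 3,5-dimethoxybenzyl and allyl on the same oxygen, yet they cannot be ranked against one another and the steps among them cannot be read, for one reason: the limit of > 20000 nM in this assay, at which 3 of the 4 values shown sit. Among these compounds, the one step that can be read, an at least 1.2-fold higher number from compound 2 to compound 4 (0.09 log units; that floor lies within the scatter), puts allyloxy in place of 4-hydroxyphenyl on a saturated chain carbon bound to two aromatic carbons, and as a floor it does not tell how far apart the two compounds really lie.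

Still open, from the compounds shown here alone, is whether any group on this oxygen can bring the read-out under the limit, for example a longer chain ending in an amine or a carboxylic acid. Also open, going by these compounds, is whether compound 2 keeps an actual number when a plain phenyl stands in place of its 4-hydroxyphenyl.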